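The compounds below may be only part of what the source reports. "The series", "measured", "known", "first", "only" and "open" are said of these compounds alone.

Measured compounds in an ADME assay on microsomes from liver (Canis lupus familiaris) for metabolic stability; a higher number here means that the compound lasts longer, a lower number that the compound disappears faster:
compound 1, `N#Cc1ccc(-c2nc(NCCNc3ccc([N+](=O)[O-])c(N)n3)ncc2-c2ncc[nH]2)cc1`, > 0.5 h
compound 2, `Nc1nc(NCCNc2ncc(-c3ncc[nH]3)c(-c3ccc(C(F)(F)F)cc3)n2)ccc1[N+](=O)[O-]`, > 0.5 h
compound 3, `Nc1nc(NCCNc2ncc(-c3ncc[nH]3)c(-c3ccc(F)cc3Br)n2)ccc1[N+](=O)[O-]`, > 0.5 h

Compound 1 stands only at a limit of this assay, not at a number, in this assay . Compound 2 likewise shows only a limit in this assay . Compound 3 as well shows only a limit in this assay . Compound 4, `Cc1ccc(-c2nc(NCCNc3ccc([N+](=O)[O-])c(N)n3)ncc2-c2ncc[nH]2)c(Br)c1`, has not yet been measured in this assay ; it differs from compound 1 in one place: 2-bromo-4-methylphenyl in place of 4-cyanophenyl on an aromatic carbon.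

For the measured compounds named here, three measured steps bear on this change, each replacing one aryl group on the same aromatic carbon: a step that the two limits leave unreadable from compound 1 to compound 2, a step that the two limits leave unreadable from compound 1 to compound 3 and a step that the two limits leave unreadable from compound 2 to compound 3. None of them can be read, because of the limit of > 0.5 h in this assay, at which 3 of the 3 values shown sit; every aryl variation tried so far stays at that limit. The change to compound 4 is of the same kind, so no step beyond the scatter is expected, and the step that the limit leaves unreadable from compound 1 to compound 4 is the expectation. Compound 4 is therefore expected to give about 1 h in this assay , within 0.5 h to 3 h, most likely again reported as a limit.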

Compound 4, half-life: > 0.5 h
Compound 4: only a limit was reported; the forecaster's own chance of this, stated with the estimate: 85%; the middle value lies beyond the limit too.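

No new step can be read from compound 4, whose result in this assay is again only a limit, so its comparisons with compound 1, compound 2 and compound 3 stay unreadable, because all share that limit: the limit of > 0.5 h in this assay, at which 4 of the 4 values shown sit. The compounds shown leave open how long each actually lasts in this assay and whether their aryl groups differ at all.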